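Swapping the five-membered ring on the shared core

The source may hold more compounds than are shown below. What is called first, only, known or untested is meant among the compounds shown, and "the series" means these compounds.

Measured so far in an in vitro functional assay on HEK285-7 cells for antagonist activity at prostaglandin D2 receptor 2 (Homo sapiens), read by BRET and beta-arrestin recruitment; a higher number here means a larger maximal response, a lower number a smaller maximal response:
- Compound 1 `O=C(O)Cc1sc(C(c2ccc(F)cc2)c2ccc(F)cc2)nc1-c1cccc(F)c1` gives 80%.
- Compound 2 `O=C(O)Cc1sc(C(c2ccc(F)cc2)c2ccc(F)cc2)nc1-c1cc(F)nc(F)c1` gives 80%.
- Compound 3 `O=C(O)Cc1sc(C(c2ccc(F)cc2)c2ccc(F)cc2)nc1-c1cn[nH]c1` gives 80%.

Compound 3 stands level with the other two: its maximal response is the same as that of compound 1 and of compound 2 at the digits shown, and the differences stay within the usual scatter of such measurements. The step now goes from compound 3 to compound 4 `O=C(O)Cc1sc(C(c2ccc(F)cc2)c2ccc(F)cc2)nc1-c1ccco1`, and its structural change is this: furan-2-yl in place of 1H-pyrazol-4-yl on an aromatic carbon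

Two measured steps speak to this kind of swap, since each of them also replaces the aromatic group at the same place on the core. They are no change at the digits printed from compound 1 to compound 3 (within the scatter) and no change at the digits printed from compound 2 to compound 3 (within the scatter). Neither moved the maximal response beyond the scatter, even though the groups swapped there differ in size, ring type and hetero atoms. Compound 4 is therefore expected to give 80%, with a range from 70% to 90%. The expected step is no change at the digits printed from compound 3 to compound 4 (within the scatter), which is estimated to stay within the scatter.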

Compound 4, largest response reached (reported as efficacy), in percent of the reference or control that the assay uses: 80%
The estimate for compound 4 equals the measured number at the digits printed; low and high end bracket the measured number.
By their numbers in this assay, from the lowest: compounds 1, 2, 3 and 4 (each within the scatter of the next).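

In this assay, furan-2-yl brings 0 hydrogen-bond donors and 1 ring hetero atom where 1H-pyrazol-4-yl had 1 donor and 2 hetero atoms, and the result is no change at the digits printed from compound 3 to compound 4 (within the scatter) for this swap, so among these compounds a hydrogen-bond donor on this group is not needed to keep the maximal response. Among these compounds, a ring oxygen also appears here for the first time at this place, and the comparisons with the other two groups read the same: no change at the digits printed from compound 2 to compound 4 (within the scatter) against 2,6-difluoropyridin-4-yl, and no change at the digits printed from compound 1 to compound 4 (within the scatter) against 3-fluorophenyl. Nothing available explains why the response holds across these swaps. As far as these compounds go, all four groups are aromatic rings, so it stays open whether a small non-ring group, such as an amine, or a longer chain at this place would keep the same response.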